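Extending the carboxamide alkyl in a pyridinone-carboxamide series

This account rests on a few compounds, and the source may have more. Where it says the series, first, only, none or still open, it means among the compounds named here.

Measured compounds:
compound 1 `CNC(=O)c1cc(Oc2ccc(NC(=O)c3cc4cccnc4n(-c4ccccc4F)c3=O)cc2)ccn1` with 590 nM
compound 2 `CNC(=O)c1cc(Oc2ccc(NC(=O)c3cc4cccnc4n(-c4ccc(Br)cc4)c3=O)cc2)ccn1` with 3710 nM
compound 3 `CNC(=O)c1cc(Oc2ccc(NC(=O)c3cc4cccnc4n(-c4ccc(OC)cc4)c3=O)cc2)ccn1` with "not determined" (no result reported)

In a functional assay on NCI-H460 cells (Homo sapiens) for antiproliferative activity, read by MTT assay, with a stated time of 72 h (a lower number here means a stronger inhibitor, a higher number a weaker inhibitor), compound 1 gives 590 nM, the lowest of the two numbers reported; compound 2 sits well away from it, since a 6.3-fold higher number from compound 1 to compound 2 (0.80 log units; beyond the scatter). For compound 3 no number was reported in this assay.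

Compound 4 `CCNC(=O)c1cc(Oc2ccc(NC(=O)c3cc4cccnc4n(-c4ccccc4F)c3=O)cc2)ccn1` differs from compound 1 by methyl in place of hydrogen on a saturated chain carbon bound to an amide-type nitrogen. Within the data shown here, the only measured step, from compound 1 to compound 2, alters the aryl group on the ring nitrogen, not the carboxamide, so it offers no direct guide to this change. Nothing in the data shows how the alkyl on the carboxamide nitrogen affects the reading in this assay. Among the measured compounds shown here, with no step bearing on it, compound 4 is expected to stay close to compound 1, the estimated step being a 1.2-fold higher number from compound 1 to compound 4 (0.07 log units; within the scatter), within the scatter in either direction. Compound 4 is therefore estimated at 700 nM in this assay, with a range from 250 nM to 2000 nM.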

Compound 4, half-maximal inhibitory concentration: 1230 nM
Estimate against measurement, compound 4: 1.8-fold (0.24 log units) below; the range from low to high includes it.
By their numbers in this assay, from the lowest: compound 1; then compound 4; then compound 2.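

In this assay, the change from methylcarbamoyl to ethylcarbamoyl gives a 2.1-fold higher number from compound 1 to compound 4 (0.32 log units; beyond the scatter). Among these compounds, this is the first reading at the carboxamide, since the earlier step changed only the aryl group on an aromatic nitrogen, and it shows that a single added methyl at this place is enough to move the number, modestly, towards weaker inhibition. Nothing among the available data explains this step.

The compounds shown leave open whether a longer chain such as propyl, a branched group such as isopropyl, or a ring such as cyclopropyl would continue in this direction, and how the unsubstituted carboxamide would read. They also leave open whether methyl to ethyl would give a similar step with 4-bromophenyl in place of 2-fluorophenyl.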